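This account rests on a few compounds, and the source may have more. Where it says the series, first, only, none or still open, it means among the compounds named here.

In a physicochemical assay for solubility, in phosphate buffer, with a stated time of 18 h (a higher number here means a more soluble compound, a lower number a less soluble compound), compound 1 `CSc1nc(C(C)(C)C)nc2nc(N)c(C#N)c(N)c12` gives 14000 nM and compound 2 `CC(C)(C)c1nc(CCCCC#N)c2c(N)c(C#N)c(N)nc2n1` gives 16000 nM which puts the two within the scatter of each other. Compound 3 `CC(C)(C)c1nc(CCCCCC#N)c2c(N)c(C#N)c(N)nc2n1` differs from compound 2 in one place (cyanomethyl in place of cyano on a saturated chain carbon, four bonds along the chain from an aromatic carbon): cyanomethyl in place of cyano on a saturated chain carbon, four bonds along the chain from an aromatic carbon. Among the measured compounds shown here, the only measured step (a 1.1-fold higher number from compound 1 to compound 2 (0.06 log units; within the scatter)) put 4-cyanobutyl in place of methylsulfanyl on an aromatic carbon, so no change beyond the scatter is expected here. The expected step is a 1.1-fold lower number from compound 2 to compound 3 (0.06 log units; within the scatter) at the centre of the estimate. For compound 3 the estimated solubility is 14000 nM (range 7000 nM to 28000 nM).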

Compound 3, solubility: 6000 nM
Estimate against measurement, compound 3: 2.3-fold (0.37 log units) above; the whole stated range lies above it.
By their numbers in this assay, from the lowest: compound 3; then compounds 1 and 2 (each within the scatter of the next).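

On this saturated chain, cyanomethyl in place of cyano changes this assay beyond the scatter, with a 2.7-fold lower number from compound 2 to compound 3 (0.43 log units; beyond the scatter). The 5-cyanopentyl group in place of methylsulfanyl on the aromatic carbon also gives a step beyond the scatter, a 2.3-fold lower number from compound 1 to compound 3 (0.37 log units; beyond the scatter), whereas the 4-cyanobutyl group of compound 2 stayed within the scatter of compound 1. A small extension at the chain end can therefore matter here, and no evidence accounts for the difference. On these data alone, whether a still longer chain goes further down stays open, as does how an amine or a carboxylic acid at the chain end would compare.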